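A few compounds are considered here, and "the series" means these few. Any claim that something is new, unique, unknown or untested is made for them only; others in the source may bear on it.

Measured in a functional assay on A549 cells (Homo sapiens) for cytotoxicity, read by MTT assay, with a stated time of 48 h; on this read-out lower numbers stand for stronger inhibition and higher numbers for weaker inhibition:
- Compound 1 `COc1ccc(-c2c[nH]c(=O)n2-c2cc(OC)c(OC)c(OC)c2)cc1`: > 50000 nM, a limit of the assay
- Compound 2 `COc1cc(NC(=O)n2cc(-c3ccc(O)cc3)n(-c3cc(OC)c(OC)c(OC)c3)c2=O)cc(OC)c1OC`: 2500 nM

Among the measured compounds shown here, compound 2, at 2500 nM, holds the only true number so far in this assay. The result for compound 1 is a limit. Compound 3 `COc1ccc(-c2cn(C(=O)Nc3cc(OC)c(OC)c(OC)c3)c(=O)n2-c2cc(OC)c(OC)c(OC)c2)cc1OC` carries 3,4-dimethoxyphenyl in place of the 4-hydroxyphenyl of compound 2 on an aromatic carbon (3,4-dimethoxyphenyl in place of 4-hydroxyphenyl on an aromatic carbon). For the measured compounds named here, no measured pair isolates this change, so no firm direction can be expected, and any shift is expected to stay within the usual scatter. The expected step is a 1.2-fold higher number from compound 2 to compound 3 (0.08 log units; within the scatter). Compound 3 is estimated at 3000 nM, with an expected range of 600 nM to 15000 nM.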

Compound 3, half-maximal inhibitory concentration: > 50000 nM
Compound 3 ended at the assay's limit (the forecaster's own chance of this, stated with the estimate: 10%); middle value at least 16-fold (1.22 log units) from the limit.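

In this assay, among the compounds shown here, the earlier compounds gave no pair that isolated this position, and the group on this aromatic carbon now proves to matter, with 3,4-dimethoxyphenyl in place of 4-hydroxyphenyl giving an at least 20-fold higher number from compound 2 to compound 3 (1.30 log units; beyond the scatter). The result for compound 3, > 50000 nM, is a limit, so the step gives only a minimum size, and this reading rests on the assay's limit: the limit of > 50000 nM in this assay, at which 2 of the 3 values shown sit.

The compounds shown leave open whether the hydroxyl group itself or the added methoxy groups drive this shift. They also leave open how an aminophenyl or a fluorophenyl would read at this carbon.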